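Replacing the Carbonyl Group on the Ring Nitrogen

The source may report more compounds than this note shows. Statements on the series, on what has been measured and on what is new or still open speak of the compounds shown alone.

Three compounds share a five-membered non-aromatic ring with 2 nitrogen and differ only in the group on the carbonyl carbon. Compound 1 `COC(=O)CC(=O)N1N=C(c2ccc(-n3ccnc3)cc2)CC1c1ccc(N(C)C)cc1` gives 2.1% in a functional assay on HCC1806 cells (Homo sapiens) for inhibition, read by sulforhodamine B assay, tested at 10 uM; a lower number here means less inhibition, a higher number more inhibition at the concentration tested (going by the name of the read-out). Compound 2 `CN(C)c1ccc(C2CC(c3ccc(-n4ccnc4)cc3)=NN2C(=O)c2ccc(F)cc2)cc1` gives 7.1%, and the step of a number 5 percentage points higher from compound 1 to compound 2 (within the scatter) is small. Compound 3 `CN(C)c1ccc(C2CC(c3ccc(-n4ccnc4)cc3)=NN2C(=O)c2cc(Cl)cc(Cl)c2)cc1` gives 44.5%, the highest of the three numbers, with a number 42.4 percentage points higher from compound 1 to compound 3 (beyond the scatter) and a number 37.4 percentage points higher from compound 2 to compound 3 (beyond the scatter) both large.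

Compound 4 `CN(C)c1ccc(C2CC(c3ccc(-n4ccnc4)cc3)=NN2S(=O)(=O)c2ccc([N+](=O)[O-])cc2)cc1` differs from compound 3 in a different way: (4-nitrophenyl)sulfonyl in place of (3,5-dichlorophenyl)carbonyl on an amine nitrogen in a ring. Within the data shown here, no measured step bears directly on this exchange, since the three steps above only vary the group on the carbonyl carbon while the carbonyl itself stays. Those steps show that the group on the ring nitrogen can move the read-out widely, so a change beyond the scatter in either direction is plausible. With the carbonyl gone, the expected number for compound 4 is 20%, between 2% and 50%, which is an expected step of a number 24.5 percentage points lower from compound 3 to compound 4 (beyond the scatter).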

Compound 4, a percentage reported as inhibition, at one concentration (the size of the read-out at that concentration, not a potency): 46.6%
Beside the measured number, compound 4's estimate is 26.6 percentage points below it; low and high end bracket the measured number.
By their numbers in this assay, from the lowest: compounds 1 and 2 (each within the scatter of the next); then compounds 3 and 4 (each within the scatter of the next).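

In this assay, the carbonyl on the ring nitrogen proves not to be needed for a high number, since (4-nitrophenyl)sulfonyl in place of (3,5-dichlorophenyl)carbonyl gives a number 2.1 percentage points higher from compound 3 to compound 4 (within the scatter). The same sulfonyl group also stands well apart from the other two acyl groups, with a number 39.5 percentage points higher from compound 2 to compound 4 (beyond the scatter) and a number 44.5 percentage points higher from compound 1 to compound 4 (beyond the scatter), both large. At this position, then, a high number is reached with either a carbonyl or a sulfonyl link, while compound 2 shows that a carbonyl link alone does not ensure one.

As far as these compounds go, because the link and the ring substituents change together between compound 3 and compound 4, their separate shares remain open, as does the reading of a (4-nitrophenyl)carbonyl or a methylsulfonyl group here. Nothing measured here explains why these two different groups read alike.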